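The compounds below may be only part of what the source reports. "The series", "measured", "known", "first", "only" and "open" are said of these compounds alone.

The measured compounds:
- compound 1 `CCc1nc(-c2cc(C)c(OCCC(C)CCN3CCN(c4ccnc(N)c4)C3=O)c(C)c2)no1`; in an ADME assay on RD cells (Homo sapiens) for cytotoxicity, read by MTT assay, with a stated time of 24 h (on this read-out lower numbers stand for higher toxicity in this test and higher numbers for lower toxicity in this test), compound 1 gives 15700 nM.
- compound 2 `CC(CCOc1ccc(-c2noc(C(F)(F)F)n2)cc1)CCN1CCN(c2ccnc(N)c2)C1=O`; in this assay compound 2 gives 48100 nM.
- compound 3 `CCO/N=C/c1ccc(OCC#CCN2CCN(c3ccnc(N)c3)C2=O)cc1`; in this assay compound 3 reaches only a limit of the test, > 100000 nM, and not a number.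

Compound 2 stands highest of the two numbers given. Its nearest neighbour is compound 1, which sits lower by a gap beyond the usual scatter, while compound 3 is known only as a limit (the limit of > 100000 nM in this assay, at which 1 of the 3 values shown sits). The step followed here leads from compound 2 to compound 4 `CCc1nc(-c2ccc(OCCC(C)CCN3CCN(c4ccnc(N)c4)C3=O)cc2)no1`, which has not yet been measured in this assay. The change is this: ethyl in place of trifluoromethyl on an aromatic carbon. Going by the values given here, no pair of measured compounds differs in exactly this way, so the expectation rests on what has been seen so far. Compound 4 shares the 5-ethyl-1,2,4-oxadiazol-3-yl group with compound 1, yet the two differ elsewhere as well, so the value of compound 1, 15700 nM, is only a loose guide. For compound 4 a step toward a somewhat lower number is expected, of about a 1.6-fold lower number from compound 2 to compound 4 (0.21 log units; within the scatter), close to the edge of the scatter. Compound 4 is thus estimated to give around 30000 nM, within a range from 10000 nM to 100000 nM.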

Compound 4, half-maximal cytotoxic concentration: > 100000 nM
Compound 4 was reported as a limit; the forecaster's own chance of this, stated with the estimate: 20%; middle value at least 3.3-fold (0.52 log units) away from the limit.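

Going by these compounds alone, this is the first direct reading of a change at this carbon of the five-membered aromatic ring: with the rest of the molecule the same, ethyl in place of trifluoromethyl gives an at least 2.0-fold higher number from compound 2 to compound 4 (0.31 log units; beyond the scatter) in this assay. The group on this carbon therefore matters for the read-out, and in this pair the ethyl group goes with the lower toxicity in this test. Compound 4 gives a limit and not a number, so the step has no upper end: the limit of > 100000 nM in this assay, at which 2 of the 4 values shown sit.

Going by these compounds, whether an amine, a methyl group or a longer chain at this carbon would also stay at the limit remains open. So does whether the same change gives a similar step on the core of compound 1, with its two extra methyl groups.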